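Compound 3 to compound 4: adding a cyclobutylmethyl link

The compounds below may be only part of what the source reports. "The series", "measured", "known", "first", "only" and "open" are said of these compounds alone.

Within the data shown here, in an ADME assay on Huh-7 cells (Homo sapiens) for cytotoxicity, with a stated time of 72 h (a higher number here means that more compound is tolerated, a lower number that less compound is tolerated), the series so far offers limits and no exact numbers. Compound 1 `CC(C)CCn1nc(-c2ccn(C)c2)c(O)c(C2=NS(=O)(=O)c3cc(NS(C)(=O)=O)ccc3N2)c1=O` gives > 1000 nM, which is a limit. Compound 2 `CC(C)CCn1nc(C2CCCCC2)c(O)c(C2=NS(=O)(=O)c3cc(NS(C)(=O)=O)ccc3N2)c1=O` gives > 1000 nM, also a limit. Compound 3 `CC(C)CCn1nc(C2CCC2)c(O)c(C2=NS(=O)(=O)c3cc(NS(C)(=O)=O)ccc3N2)c1=O` gives > 33000 nM, again a limit, and the only one at this level among the three.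

Compound 4 `CC(C)CCn1nc(CC2CCC2)c(O)c(C2=NS(=O)(=O)c3cc(NS(C)(=O)=O)ccc3N2)c1=O` carries cyclobutylmethyl in place of cyclobutyl on an aromatic carbon.

Among the measured compounds shown here, three measured steps bear on this change, all of them swaps at the same carbon: a step that the two limits leave unreadable from compound 1 to compound 2, a step that the two limits leave unreadable from compound 1 to compound 3 and a step that the two limits leave unreadable from compound 2 to compound 3. None of them gives a size, so none supports a direction. No step beyond the scatter is therefore expected in this assay, and the expectation rests on compound 3, whose > 33000 nM is a limit. The expected change is a number no higher from compound 3 to compound 4 (the limit leaves the size open). A report as a limit is also the likely outcome.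

Compound 4 is estimated at 33000 nM, within an expected range of 10000 nM to 70000 nM.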

Compound 4, half-maximal cytotoxic concentration: > 33000 nM
Compound 4: only a limit was reported; the forecaster's own chance of this, stated with the estimate: 85%; the middle value lies on the limit itself.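

Compound 4 gives > 33000 nM, which is a limit. Among these compounds, the values of compound 1, compound 2 and compound 3 are limits too, so no step to compound 4 can be read. The compounds shown leave open how the group on this aromatic carbon changes the tolerated concentration in this assay.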